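The compounds below may be only part of what the source reports. "The series", "measured", "known", "first", "only" and "open" are said of these compounds alone.

In a functional assay on aorta (Rattus norvegicus) (on this read-out higher numbers stand for weaker inhibition and lower numbers for stronger inhibition), compound 1, `CC(C)(C)[Si](OCCCc1ccc(=O)[nH]n1)(c1ccccc1)c1ccccc1`, gives 78300 nM. Compound 2, `Cn1nc(CCCO[Si](c2ccccc2)(c2ccccc2)C(C)(C)C)ccc1=O`, is reported in this assay only as a limit, > 100000 nM. Among the measured compounds shown here, the one measured step, an at least 1.2-fold higher number from compound 1 to compound 2 (0.10 log units; that floor lies within the scatter), is therefore known only as a floor; that compound 2 sits at the limit of > 100000 nM in this assay, at which 1 of the 2 values shown sits, means its true value is not pinned down. Compound 3, `CC(C)(C)[Si](OCCCc1ccc(=O)n(Cc2ccccc2)n1)(c1ccccc1)c1ccccc1`, differs from compound 2 by phenyl in place of hydrogen on a saturated chain carbon bound to an aromatic nitrogen. For the measured compounds named here, the only step that bears on this change is the one from compound 1 to compound 2, and it offers no numeric anchor beyond a floor that lies within the scatter, so no direction can be read from it for the phenyl addition. Compound 3 is accordingly expected to remain near the weak end of this assay, with a step of a number no higher from compound 2 to compound 3 (the limit leaves the size open) estimated for it. The estimate for compound 3 in this assay is 100000 nM, within a range from 20000 nM to 400000 nM, with a considerable chance that again only a limit is reported.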

Compound 3, half-maximal inhibitory concentration: 39900 nM
The estimate for compound 3 lay 2.5-fold (0.40 log units) above the measured number, and the stated range covers the measured number.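

With benzyl in place of methyl on the aromatic nitrogen, this position gives its first step that can be read as a change in this assay: an at least 2.5-fold lower number from compound 2 to compound 3 (0.39 log units; beyond the scatter). Benzyl in place of hydrogen on the same nitrogen shows no such separation, a 2.0-fold lower number from compound 1 to compound 3 (0.29 log units; within the scatter), so the substituent-free compound 1 and the benzyl compound 3 cannot be ordered. The phenyl step thus sets benzyl apart from methyl only, and its size is a floor, since compound 2 is reported only as a limit: the limit of > 100000 nM in this assay, at which 1 of the 3 values shown sits.

On these data alone, whether an amine, a carboxylic acid or a longer chain on that saturated chain carbon would move the number further remains open. As far as these compounds go, the true value of compound 2, and with it the full size of the phenyl step, also stays unknown.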